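Carbamate in place of furoyl-aminopropyl ether on the shared core

This account rests on a few compounds, and the source may have more. Where it says the series, first, only, none or still open, it means among the compounds named here.

Measured so far:
- compound 1 `CC(C)=CCC/C(C)=C/CC1Cc2c(O)cc(=O)n(CCCO)c2CC1(C)C`: 28.7%
- compound 2 `CC(C)=CCC1Cc2c(OCCCNC(=O)c3ccco3)cc(=O)n(CCCO)c2CC1(C)C`: 2.1%

In a functional assay on PANC-1 cells (Homo sapiens) for inhibition, read by MTT assay, with a stated time of 24 h, tested at 10 uM (on this read-out lower numbers stand for less inhibition and higher numbers for more inhibition at the one concentration tested (going by the name of the read-out)), compound 2 gives 2.1% and stands lowest of the two numbers; compound 1, at 28.7%, lies beyond the scatter above it. For the measured compounds named here, the two compounds differ in several places, so no single step is described between them; their values show only that compound 1 inhibits more at the tested concentration.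

Compound 3 `CC(C)=CCC1Cc2c(OC(=O)Nc3ccc(Cl)c(Cl)c3)cc(=O)n(CCCO)c2CC1(C)C` keeps the core of compound 2 and changes one place: (3,4-dichlorophenyl)carbamoyl in place of 3-(((furan-2-yl)carbonyl)amino)propyl on an oxygen on an aromatic ring. Going by the values given here, there is no measured pair to read the size of this change from. Among the compounds with values here, the expected step of a number 12.9 percentage points higher from compound 2 to compound 3 (beyond the scatter) is a modest rise, within what the two numbers so far span, but with wide uncertainty in either direction.

Compound 3 is estimated at 15% in this assay, with a range from 0% to 45%.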

Compound 3, a percentage reported as inhibition, at one concentration (the size of the read-out at that concentration, not a potency): 61.4%
Beside the measured number, compound 3's estimate is 46.4 percentage points below it, and the stated range ends below it.
By their numbers in this assay, from the lowest: compound 2; then compound 1; then compound 3.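

In this assay, for the compounds shown here, (3,4-dichlorophenyl)carbamoyl in place of 3-(((furan-2-yl)carbonyl)amino)propyl on an oxygen on an aromatic ring gives a number 59.3 percentage points higher from compound 2 to compound 3 (beyond the scatter) and is the only single-place step that can be read. This position therefore has a large effect on inhibition at the one concentration tested, and the heavy-atom count does not separate the two groups, which hold the same number. Nothing at hand bears on the reason for the size of this step.

On these data alone, the carbamoyl link and the dichlorophenyl ring enter together, so the share of each in the step stays open. Also open, as far as these compounds go, is how the read-out responds at this position to an unsubstituted phenyl carbamoyl, a single chlorine on the ring, or a ring bearing an amine or a carboxylic acid.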